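From 3-fluorobenzyl to methyl

This account rests on a few compounds, and the source may have more. Where it says the series, first, only, none or still open, it means among the compounds named here.

In a functional assay on Bel7402/5-FU cells (Homo sapiens) for antiproliferative activity, read by MTT assay, with a stated time of 72 h (on this read-out lower numbers stand for stronger inhibition and higher numbers for weaker inhibition), compound 1 `C=C1C(=O)O[C@H]2[C@H]1CC/C(COC(=O)CCC(=O)NCCCCCCNC(=O)Cn1cc(F)c(=O)n(Cc3ccccc3)c1=O)=C\CC[C@@]1(C)O[C@@H]21` gives 16200 nM and compound 2 `C=C1C(=O)O[C@H]2[C@H]1CC/C(COC(=O)Cn1cc(F)c(=O)n(Cc3cccc(F)c3)c1=O)=C\CC[C@@]1(C)O[C@@H]21` gives 3700 nM as the lower of the two numbers, so compound 2 is the stronger inhibitor of this pair. Compound 3 `C=C1C(=O)O[C@H]2[C@H]1CC/C(COC(=O)Cn1cc(F)c(=O)n(C)c1=O)=C\CC[C@@]1(C)O[C@@H]21` keeps the rest of compound 2 and changes one place, with hydrogen in place of 3-fluorophenyl on a saturated chain carbon bound to an aromatic nitrogen turning 3-fluorobenzyl to methyl on a saturated chain carbon bound to an aromatic nitrogen. For the measured compounds named here, no measured pair shows this single change, so any forecast is loose. In this assay the expected move is a 1.6-fold higher number from compound 2 to compound 3 (0.21 log units; within the scatter) towards modestly weaker inhibition. Compound 3 is estimated at 6000 nM with a range from 2000 nM to 20000 nM as the likely span.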

Compound 3, half-maximal inhibitory concentration: 11700 nM
For compound 3 the middle estimate is 2.0-fold (0.29 log units) below the measured one, and the stated range covers the measured number.
By their numbers in this assay, from the lowest: compound 2; then compounds 3 and 1 (each within the scatter of the next).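

Putting methyl in place of 3-fluorobenzyl, on a saturated chain carbon bound to an aromatic nitrogen, gives a 3.2-fold higher number from compound 2 to compound 3 (0.50 log units; beyond the scatter) in this assay and so weaker inhibition. For the compounds shown here, this is the first direct reading of this position, and it shows that losing the 3-fluorophenyl part has a modest cost that lies beyond the usual scatter. No evidence is available to explain this change.

Still open, going by these compounds, is whether the ring or its fluorine accounts for the step. A plain benzyl group, or a butyl chain in place of methyl, on the core of compound 2 would help separate the two.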